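Swapping Tert-Butyl for Bromo on Two Related Cores

The compounds below may be only part of what the source reports. "The series", "measured", "known", "first", "only" and "open" are said of these compounds alone.

Compound 1 `COc1ccc(/C=C2/CN(C)/C(=N/c3ccc(C(C)(C)C)cc3)S2)cc1` and compound 2 `COc1ccc(/C=C2/CN(C)/C(=N/c3ccc(Br)cc3)S2)cc1` share one core, while compound 3 `COc1ccc(/C=C2\S/C(=N\c3ccc(C(C)(C)C)cc3)N(C)C2=O)cc1` and compound 4 `COc1ccc(/C=C2\S/C(=N\c3ccc(Br)cc3)N(C)C2=O)cc1` share another; the difference between the two cores is not broken down here. In a functional assay on MCF7 cells (Homo sapiens) for antiproliferative activity, read by MTT assay, with a stated time of 72 h (a higher number here means a weaker inhibitor, a lower number a stronger inhibitor), compound 1 gives 28700 nM. Compound 2 gives 7400 nM in this assay. For the measured compounds named here, the one change between them is bromo in place of tert-butyl on an aromatic carbon and it gave a 3.9-fold lower number from compound 1 to compound 2 (0.59 log units; beyond the scatter). For compound 3 this assay reports only a limit, > 100000 nM. The change from compound 3 to compound 4 is bromo in place of tert-butyl on an aromatic carbon, the same change in the same place. As far as these compounds go, because compound 3 sits at the limit of > 100000 nM in this assay, at which 1 of the 3 values shown sits, the true starting point is unknown, so the step can only be guessed. If the earlier step repeats, a step of an at least 2.5-fold lower number from compound 3 to compound 4 (0.39 log units; beyond the scatter) is expected. Compound 4 is therefore estimated at about 40000 nM, plausibly between 12000 nM and 150000 nM.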

Compound 4, half-maximal inhibitory concentration: > 100000 nM
Compound 4 ended at the assay's limit; the forecaster's own chance of this, stated with the estimate: 40%; middle value at least 2.5-fold (0.39 log units) from the limit.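

Compound 3 and compound 4 both stand at a limit in this assay and not at a number, so the step between them cannot be read: the limit of > 100000 nM in this assay, at which 2 of the 4 values shown sit. Still open, as far as these compounds go, is whether bromo in place of tert-butyl changes activity on the core of compound 3 as it does on the core of compound 1.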